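Phenylsulfonyl for (3-methylphenyl)carbonyl on the shared core

The source may hold more compounds than are shown below. What is called first, only, known or untested is meant among the compounds shown, and "the series" means these compounds.

Two compounds of this series carry a number in an ADME assay on Li23 cells (Homo sapiens) for cytotoxicity, read by WST assay; a lower number here means that less compound is tolerated, a higher number that more compound is tolerated. Compound 1 `Cc1cccc(C(=O)N(C)c2ccc(C(O)(C(F)(F)F)C(F)(F)F)cc2)c1` gives 20000 nM and serves as the reference point. Compound 2 `CCN(C(=O)c1ccccc1)c1ccc(C(O)(C(F)(F)F)C(F)(F)F)cc1` gives 19000 nM, a reading that lies within the scatter of compound 1, so the two numbers cannot be told apart. Compound 3 `CN(c1ccc(C(O)(C(F)(F)F)C(F)(F)F)cc1)S(=O)(=O)c1ccccc1` is not yet measured. Against compound 1 it differs in one place: phenylsulfonyl in place of (3-methylphenyl)carbonyl on a nitrogen on an aromatic ring. Going by the values given here, no step between measured compounds has been recorded, so the series itself offers no precedent for the size of this change. Given that compound 1 and compound 2 sit together, the step is expected to be small, and no direction beyond the scatter is anticipated. The expected step of a 1.1-fold lower number from compound 1 to compound 3 (0.05 log units; within the scatter) is therefore modest. Compound 3 is estimated at 18000 nM in this assay, with a range from 8000 nM to 40000 nM.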

Compound 3, half-maximal cytotoxic concentration: 16000 nM
Beside the measured number, compound 3's estimate is 1.1-fold (0.05 log units) above it; the measured number falls inside the stated range.
By their numbers in this assay, from the lowest: compounds 3, 2 and 1 (each within the scatter of the next).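

In this assay the series now has its first step in one place, a 1.3-fold lower number from compound 1 to compound 3 (0.10 log units; within the scatter), so this exchange on a nitrogen on an aromatic ring cannot be told apart from no change at all. Phenylsulfonyl thus stands in for (3-methylphenyl)carbonyl with no measurable consequence here, even though the exchange replaces the carbonyl with a sulfonyl and removes the methyl on the ring in a single step. No measurement at hand bears on this reading.

Going by these compounds alone, the single step does not separate the part played by the sulfonyl from that of the methyl. As far as these compounds go, whether any group at this place can shift the reading beyond the scatter remains open, for instance a carboxylic acid, an amine or a longer chain on the aromatic ring.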